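Sulfur-linked heteroaryl variation on a shared anilide core

A few compounds are considered here, and "the series" means these few. Any claim that something is new, unique, unknown or untested is made for them only; others in the source may bear on it.

Measured compounds:
compound 1 `Cn1c(-c2ccc(NC(=O)CSc3nc4cc(Cl)ccc4o3)cc2)nc(-c2ccccc2)c1-c1ccccc1` gives 79.6%
compound 2 `Cc1ccc2oc(SCC(=O)Nc3ccc(-c4nc(-c5ccccc5)c(-c5ccccc5)n4C)cc3)nc2c1` gives 69.8%
compound 3 `Cn1cnnc1SCC(=O)Nc1ccc(-c2nc(-c3ccccc3)c(-c3ccccc3)n2C)cc1` gives 88%

All three were read in a functional assay on HT-29 cells (Homo sapiens) for cytotoxicity, read by MTT assay, with a stated time of 24 h, tested at 80 ug/mL; on this read-out lower numbers stand for a weaker effect and higher numbers for a stronger effect at the one concentration tested. Within the data shown here, compound 3 holds the highest number of the three, yet the gap to compound 1 is within the scatter; only the step of a number 18.2 percentage points higher from compound 2 to compound 3 (beyond the scatter) lies beyond it. Compound 4 `Cn1ccnc1SCC(=O)Nc1ccc(-c2nc(-c3ccccc3)c(-c3ccccc3)n2C)cc1` is the next entry: 1-methyl-1H-imidazol-2-yl in place of 4-methyl-4H-1,2,4-triazol-3-yl on a sulfur. Among the measured compounds shown here, the steps that bear on this sulfur position, a number 8.4 percentage points higher from compound 1 to compound 3 (within the scatter) and a number 18.2 percentage points higher from compound 2 to compound 3 (beyond the scatter), were at most modest, and no measured pair swaps one small azole for another, so no step beyond the scatter is expected here, with a slight downward lean. Compound 4 is estimated at 82%, between 66% and 94%, meaning an expected a number 6 percentage points lower from compound 3 to compound 4 (within the scatter).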

Compound 4, a percentage reported as activity, at one concentration (the size of the read-out at that concentration, not a potency): 69.4%
Compound 4: middle estimate off by 12.6 percentage points, on the high side; the range from low to high includes it.
By their numbers in this assay, from the lowest: compounds 4, 2, 1 and 3 (each within the scatter of the next, the first and the last beyond it).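

In this assay, 1-methyl-1H-imidazol-2-yl in place of 4-methyl-4H-1,2,4-triazol-3-yl on the sulfur gives a real change (a number 18.6 percentage points lower from compound 3 to compound 4 (beyond the scatter)), so one small azole cannot be assumed interchangeable with another here. Against the fused groups the result splits: the step from the 5-methyl-1,3-benzoxazol-2-yl compound stays small (a number 0.4 percentage points lower from compound 2 to compound 4 (within the scatter)), while the step from the 5-chloro-1,3-benzoxazol-2-yl compound does not (a number 10.2 percentage points lower from compound 1 to compound 4 (beyond the scatter)). Nothing available accounts for these differences.

From the compounds shown here alone, whether the azole result extends to other groups on this sulfur remains open. A pyridin-2-yl group or a plain ethyl chain there would test it.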